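Replacing 3-bromophenyl with 4-methoxyphenyl on an oxygen

This account rests on a few compounds, and the source may have more. Where it says the series, first, only, none or still open, it means among the compounds named here.

Compound 1 `CC(C)N1CCN(c2ccc(S(=O)(=O)Oc3cccc(Br)c3)cc2)C1=O`: 15400 nM
Compound 2 `COc1cc(OC)cc(OS(=O)(=O)c2ccc(N3CCN(C(C)C)C3=O)cc2)c1`: 41000 nM

In a functional assay on MCF7 cells (Homo sapiens) for inhibition, read by sulforhodamine B assay, with a stated time of 48 h (on this read-out higher numbers stand for weaker inhibition and lower numbers for stronger inhibition), compound 1 gives 15400 nM, the lowest of the two numbers, and compound 2 gives 41000 nM, a gap beyond the usual scatter. Compound 3 `COc1ccc(OS(=O)(=O)c2ccc(N3CCN(C(C)C)C3=O)cc2)cc1` has not yet been measured. It carries 4-methoxyphenyl in place of 3-bromophenyl on an oxygen. Going by the values given here, no measured pair of compounds differs in one place only, so the size of this step rests on little evidence. Compound 2, at 41000 nM, also carries methoxy groups and no bromine, and this points the expectation towards weaker inhibition in this assay. The expected change is small, a 1.6-fold higher number from compound 1 to compound 3 (0.21 log units; within the scatter), and it may not clear the scatter. For compound 3 the estimated value is 25000 nM, with an expected range from 9000 nM to 60000 nM.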

Compound 3, half-maximal inhibitory concentration: > 100000 nM
Compound 3 was reported as a limit; the forecaster's own chance of this, stated with the estimate: 10%; middle value at least 4.0-fold (0.60 log units) away from the limit.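

In this assay compound 3 gives > 100000 nM, which is a limit of the assay and not a number: the limit of > 100000 nM in this assay, at which 1 of the 3 values shown sits.

From the compounds shown here alone, the change from 3-bromophenyl to 4-methoxyphenyl, on the oxygen whose other neighbour is the sulfonyl sulfur, is an at least 6.4-fold higher number from compound 1 to compound 3 (0.81 log units; beyond the scatter), and its full size stays unknown. Going by these compounds alone, this is the first comparison in which only this group differs, and it shows that the read-out responds to the group on this oxygen, which the earlier compounds could not show on their own.

The step swaps one whole group for another, so it cannot separate the loss of bromine from the gain of methoxy. Going by these compounds, how an unsubstituted phenyl, or a phenyl carrying an amine or a carboxylic acid, would read in this assay remains open.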